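A few compounds are considered here, and "the series" means these few. Any claim that something is new, unique, unknown or untested is made for them only; others in the source may bear on it.

Working notes on the thiosemicarbazide series.

Compound 1 `CC1=CC[C@@H]([C@@](C)(O)CCCC(C)(C)NC=S)CC1` is the parent with a bare hydrogen on the thiocarbonyl carbon; in a functional assay on UACC-62 cells (Homo sapiens) for cytotoxicity, read by sulforhodamine B assay (on this read-out lower numbers stand for stronger inhibition of growth and higher numbers for weaker inhibition of growth), compound 1 gives 9960 nM. Compound 2 `CC1=CC[C@@H]([C@@](C)(O)CCCC(C)(C)NC(=S)N/N=C\c2ccccc2)CC1` carries a group of 9 heavy atoms there instead, and in this assay compound 2 gives 12700 nM. Going by the values given here, the only step on record, a 1.3-fold higher number from compound 1 to compound 2 (0.11 log units; within the scatter), is within the scatter, so the added group left the read-out unchanged for practical purposes. Compound 2 stands at one end of the two numbers shown, with compound 1 its only neighbour and within the scatter of it.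

Compound 3 `CC1=CC[C@@H]([C@@](C)(O)CCCC(C)(C)NC(=S)N/N=C\c2ccc(O)cc2)CC1` is the next point. It differs from compound 2 as follows: hydroxy in place of hydrogen on an aromatic carbon. Among the compounds with values here, no measured step touches an aromatic carbon of the six-membered ring; the single step available sits on the thiocarbonyl carbon and was itself within the scatter. There is therefore nothing in these numbers to support a shift in either direction, and the expectation is a step of a 1.1-fold lower number from compound 2 to compound 3 (0.02 log units; within the scatter), that is, none beyond the scatter. Compound 3 is accordingly estimated at 12000 nM, with a range from 5000 nM to 30000 nM.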

Compound 3, concentration for 50% growth inhibition: 8870 nM
Estimate against measurement, compound 3: 1.4-fold (0.13 log units) above; the range from low to high includes it.
By their numbers in this assay, from the lowest: compounds 3, 1 and 2 (each within the scatter of the next).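

In this assay, going by these compounds alone, hydroxy in place of hydrogen on an aromatic carbon, para to a large group, gives a 1.4-fold lower number from compound 2 to compound 3 (0.16 log units; within the scatter) and thus provides the first reading for a change on the six-membered aromatic ring itself. The phenyl to 4-hydroxyphenyl change therefore does not separate the two compounds on this read-out, and a hydrogen-bond donor and acceptor can enter at this ring carbon without a step beyond the scatter. Together with the earlier step, a 1.3-fold higher number from compound 1 to compound 2 (0.11 log units; within the scatter) on the thiocarbonyl carbon, this leaves both changes on record within the scatter, so neither one yet marks a place in the series where the read-out responds; no supporting measurement is available to explain this result.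

Still open, going by these compounds, is whether an amine, a carboxylic acid, a methoxy group or a chlorine atom at this same ring carbon would give a step beyond the scatter, or whether this position stays flat for groups other than hydroxy. Also open, on these data alone, is whether hydroxy on another carbon of the ring, or a second hydroxy, would behave as this single substitution does.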